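Cyclopentyl to tert-butyl on the thioamide nitrogen

The source may hold more compounds than are shown below. What is called first, only, known or untested is meant among the compounds shown, and "the series" means these compounds.

Within the data shown here, compound 2 `Nc1sc(-c2ccc(Cl)cc2)c(-c2ccc(Cl)cc2)c1C(=S)NC1CCCC1` gives 29000 nM in a functional assay on PC-3 cells (Homo sapiens) for cytotoxicity, read by sulforhodamine B assay, with a stated time of 72 h (on this read-out higher numbers stand for weaker inhibition and lower numbers for stronger inhibition), the higher of the two numbers so far. Compound 1 `Nc1sc(-c2ccc(Cl)cc2)c(-c2ccc(Cl)cc2)c1C(=O)N1CCCC1` gives 6220 nM in this assay, and the step of a 4.7-fold higher number from compound 1 to compound 2 (0.67 log units; beyond the scatter) separates them. Compound 3 `CC(C)(C)NC(=S)c1c(N)sc(-c2ccc(Cl)cc2)c1-c1ccc(Cl)cc1` differs from compound 2 by tert-butyl in place of cyclopentyl on an amide-type nitrogen. Among the measured compounds shown here, no measured step changes only that group: the single step known, a 4.7-fold higher number from compound 1 to compound 2 (0.67 log units; beyond the scatter), concerns a different part of the molecule and bears only loosely here. The step expected is therefore no change at the digits printed from compound 2 to compound 3 (within the scatter), not beyond the scatter. Compound 3 is estimated at 29000 nM, within a range of 10000 nM to 85000 nM.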

Compound 3, half-maximal inhibitory concentration: 34000 nM
Compound 3: middle estimate off by 1.2-fold (0.07 log units), on the low side; the measured number falls inside the stated range.
By their numbers in this assay, from the lowest: compound 1; then compounds 2 and 3 (each within the scatter of the next).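

In this assay, the step of a 1.2-fold higher number from compound 2 to compound 3 (0.07 log units; within the scatter) shows that, on this amide-type nitrogen, tert-butyl can stand in place of cyclopentyl without a change beyond the scatter, so the ring is not needed there for this reading. The step of a 5.5-fold higher number from compound 1 to compound 3 (0.74 log units; beyond the scatter) leaves compound 3, like compound 2, beyond the scatter from compound 1. Nothing available gives a reason for either step.

Open, on these data alone, is how a longer chain, such as n-hexyl, or a primary amine on that nitrogen would read. As far as these compounds go, the step from compound 1 changes the carbonyl and the nitrogen substituent together, and their separate shares remain unknown.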